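This account rests on a few compounds, and the source may have more. Where it says the series, first, only, none or still open, it means among the compounds named here.

Compound 1 `COc1ccc(CN(C(=O)CSC(=S)N2CCN(C(=O)OC(C)(C)C)CC2)c2cc(OC)c(OC)c(OC)c2)cc1`: 310 nM in a functional assay on MGC-803 cells (Homo sapiens) for inhibition, read by CCK-8 assay, with a stated time of 48 h; a lower number here means a stronger inhibitor, a higher number a weaker inhibitor.
Compound 2 `COc1ccc(CN(C(=O)CSC(=S)N2CCN(C(=O)OC(C)(C)C)CC2)c2ccc(OC)cc2)cc1`: > 20000 nM, a limit rather than a number.

Compound 1 holds the only number shown in this assay; the other value is a limit (the limit of > 20000 nM in this assay, at which 1 of the 2 values shown sits). For the measured compounds named here, the single measured step, an at least 64-fold higher number from compound 1 to compound 2 (1.80 log units; beyond the scatter), changed the ring on the amide-type nitrogen and leaves the benzyl ring untouched. Going by the values given here, compound 3 `COc1ccc(CN(C(=O)CSC(=S)N2CCN(C(=O)OC(C)(C)C)CC2)c2cc(OC)c(OC)c(OC)c2)cc1N=[N+]=[N-]` differs from compound 1 by azido in place of hydrogen on an aromatic carbon, a change on the benzyl ring on which no measured step bears. No step beyond the scatter is therefore expected in this assay from compound 1 to compound 3, in either direction. Compound 3 is estimated at 400 nM, range 120 nM to 1500 nM, meaning a 1.3-fold higher number from compound 1 to compound 3 (0.11 log units; within the scatter).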

Compound 3, half-maximal inhibitory concentration: 810 nM
For compound 3 the middle estimate is 2.0-fold (0.31 log units) below the measured one, within the range that was stated.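

The benzyl ring now has a measured step of its own: in this assay, azido in place of hydrogen gives a 2.6-fold higher number from compound 1 to compound 3 (0.42 log units; beyond the scatter), which is modest but beyond the scatter. Azido is therefore accepted on this aromatic carbon, ortho to a methoxy group, at a modest cost in potency. Nothing at hand accounts for this step.

Going by these compounds, it remains open whether the cost belongs to azido itself or to any substituent on this carbon; an amine, fluorine or nitrile there would separate the two. On these data alone, whether azido has the same effect with other groups on the amide-type nitrogen also remains open.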